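This account rests on a few compounds, and the source may have more. Where it says the series, first, only, none or still open, it means among the compounds named here.

Measured compounds in a functional assay on HL-60 cells (Homo sapiens) for cytotoxicity, read by MTT assay, with a stated time of 72 h; a higher number here means a weaker inhibitor, a lower number a stronger inhibitor:
compound 1 `O=S(=O)(c1ccccc1)c1nc2ccccc2nc1N1CCc2ccccc2C1` gives 880 nM
compound 2 `Cc1ccc(S(=O)(=O)c2nc3ccccc3nc2N2CCc3ccccc3C2)cc1` gives 3610 nM
compound 3 `O=S(=O)(c1ccccc1)c1nc2ccccc2nc1N1CCCC(O)C1` gives 3020 nM

Compound 1 and compound 3 share a sulfonyl-bearing core but carry different amines on it; the difference between the two cores is not broken down here. Their values place compound 3 at a higher number than compound 1, and compound 3 and compound 2 lie within the usual scatter of each other.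

One change appears twice in this set. From compound 1 to compound 2 the change is methyl in place of hydrogen on an aromatic carbon, and in this assay it produced a 4.1-fold higher number from compound 1 to compound 2 (0.61 log units; beyond the scatter). The same change, (methyl in place of hydrogen on an aromatic carbon), leads from compound 3 to the unmeasured compound 4 `Cc1ccc(S(=O)(=O)c2nc3ccccc3nc2N2CCCC(O)C2)cc1`; both place descriptions read the same word for word, so this is the same change, here made on the core of compound 3 rather than on the core of compound 1.

Among the compounds with values here, with a single prior instance, and on a different core, the step for compound 4 is expected to be of a similar direction and size, a 3.1-fold higher number from compound 3 to compound 4 (0.50 log units; beyond the scatter) in this assay, because the step of a 4.1-fold higher number from compound 1 to compound 2 (0.61 log units; beyond the scatter) is the only measured guide; whether the amine part alters the outcome is not known from these three compounds. Compound 4 is therefore expected to give about 9500 nM in this assay, with a plausible range from 3500 nM to 26000 nM.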

Compound 4, half-maximal inhibitory concentration: 6080 nM
Compound 4: the middle estimate sits 1.6-fold (0.19 log units) above what was measured, and the stated range covers the measured number.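

In this assay, the change from phenyl to 4-methylphenyl on the core of compound 3 gives a 2.0-fold higher number from compound 3 to compound 4 (0.30 log units; within the scatter), and the two steps for this change cannot be told apart: the same change on two cores in this assay, a 4.1-fold higher number (0.61 log units; beyond the scatter) from compound 1 to compound 2 and a 2.0-fold higher number (0.30 log units; within the scatter) from compound 3 to compound 4, 2.0-fold (0.31 log units) apart, within the scatter of two such steps. Within the data shown here, on these two cores, the change therefore carries over with no measurable difference in its size, and the number goes up both times, although only the step on the core of compound 1 lies beyond the scatter. This does not show that the step is truly the same size on both cores, nor that it is a real effect on the core of compound 3, and two pairs give no general rule; the amine exchange with the methyl in place, a 1.7-fold higher number from compound 2 to compound 4 (0.23 log units; within the scatter), is also within the scatter, so compound 2 and compound 4 cannot be separated.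

The compounds shown leave open whether another group in the same place on the phenyl, such as chloro, methoxy or a longer chain such as ethyl, would give a step of similar size. They also leave open whether the methyl step would hold on a core carrying a different amine, such as morpholin-4-yl or a piperazine.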